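A Sulfamoyl Group Replaces Dimethylamino in Compound 4

A few compounds are considered here, and "the series" means these few. Any claim that something is new, unique, unknown or untested is made for them only; others in the source may bear on it.

Three compounds built on a shared core have gone through a functional assay on the whole organism (strain Sprague-Dawley) for inhibition, with Rattus norvegicus as the target, with a stated time of 10 min; a lower number here means that less compound is needed, a higher number that more compound is needed for the effect. Compound 1 `CCOC(=O)c1ccc(OCC)c(-c2ncc(C(=O)OCC)c(=O)[nH]2)c1` gives 1 mg/kg, and compound 2 `CCOC(=O)c1cnc(-c2cc(N)ccc2OCC)[nH]c1=O` gives 0.5 mg/kg. For compound 3 `CCOC(=O)c1cnc(-c2cc(N(C)C)ccc2OCC)[nH]c1=O` the entry reads "not determined" (no result reported), so compound 3 has no place on this scale and offers no number to start from.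

The next compound, compound 4 `CCOC(=O)c1cnc(-c2cc(S(=O)(=O)N(C)C(C)C)ccc2OCC)[nH]c1=O`, differs from compound 3 in one place: isopropyl(methyl)sulfamoyl in place of dimethylamino on an aromatic carbon. Isopropyl(methyl)sulfamoyl stands in place of dimethylamino on an aromatic carbon, para to an ethoxy group.

For the measured compounds named here, only one measured step offers any guidance, and that guidance is indirect. Going by the values given here, it swaps amino in for ethoxycarbonyl on an aromatic carbon, and no measured compound carries a sulfamoyl group. Going by a 2.0-fold lower number from compound 1 to compound 2 (0.30 log units; within the scatter), which lies within the scatter, no shift of a particular size or direction can be expected in this assay. The expectation is therefore a number in the same region as the two measured values, with a wide margin for a group not yet tested. Compound 4 is expected at about 0.8 mg/kg, with an estimated range from 0.15 mg/kg to 4 mg/kg.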

Compound 4, dose for 50% inhibition: > 10 mg/kg
Compound 4 was reported as a limit; the forecaster's own chance of this, stated with the estimate: 5%; middle value at least 12-fold (1.09 log units) from the limit.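

Compound 4 is reported in this assay only as a limit and not as an exact number: the limit of > 10 mg/kg in this assay, at which 1 of the 4 values shown sits.

Putting isopropyl(methyl)sulfamoyl on this aromatic carbon, para to an ethoxy group, gives an at least 20-fold higher number from compound 2 to compound 4 (1.30 log units; beyond the scatter) when it takes the place of amino, and an at least 10-fold higher number from compound 1 to compound 4 (1.00 log units; beyond the scatter) when it takes the place of ethoxycarbonyl. These steps show that the group on this carbon can matter in this whole-animal test, which the earlier comparison could not show, since a 2.0-fold lower number from compound 1 to compound 2 (0.30 log units; within the scatter) gave no clear difference. The step from compound 3 to compound 4 cannot be read, since compound 3 has no value.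

The compounds shown do not separate the sulfonyl part of the new group from the isopropyl and methyl groups on its nitrogen, so it stays open whether a plain sulfamoyl group would behave like amino or like the group in compound 4. On these data alone, how a carboxylic acid or an acetamide on the same carbon would compare also remains open.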